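A few compounds are considered here, and "the series" means these few. Any claim that something is new, unique, unknown or untested is made for them only; others in the source may bear on it.

Measured in a functional assay on HOP-62 cells (Homo sapiens) for inhibition, read by sulforhodamine B assay; on this read-out higher numbers stand for weaker inhibition of growth and lower numbers for stronger inhibition of growth:
Compound 1 `COc1cc(-c2ccc(-c3ccc(-c4nc5cc(C)ccc5[nH]4)cc3)cc2)cc(OC)c1OC`: 2370 nM
Compound 2 `COc1ccc(-c2ccc(-c3ccc(-c4nc5ccccc5[nH]4)cc3)cc2)cc1`: 100000 nM
Compound 3 `Oc1cccc2[nH]c(-c3ccc(-c4ccc(-c5ccc(F)cc5)cc4)cc3)nc12`: 8310 nM

Among these three, compound 3 has the second highest number, and its gaps to the other two lie beyond the usual scatter. Compound 4 `COc1ccc(-c2ccc(-c3ccc(-c4nc5c(O)cccc5[nH]4)cc3)cc2)cc1OC` differs from it in one place, on an aromatic carbon para to a large group: 3,4-dimethoxyphenyl in place of 4-fluorophenyl (3,4-dimethoxyphenyl in place of 4-fluorophenyl on an aromatic carbon). Going by the values given here, no measured pair isolates such a change. Compound 1 at 2370 nM and compound 2 at 100000 nM both carry methoxy groups, yet they fall on opposite sides of compound 3. In this assay, the expected change is therefore none beyond the scatter, with the estimated step of a 1.4-fold lower number from compound 3 to compound 4 (0.14 log units; within the scatter). Compound 4 is estimated at 6000 nM, with an expected range of 1500 nM to 30000 nM.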

Compound 4, concentration for 50% growth inhibition: 2210 nM
The estimate for compound 4 lay 2.7-fold (0.43 log units) above the measured number, and the stated range covers the measured number.
By their numbers in this assay, from the lowest: compounds 4 and 1 (each within the scatter of the next); then compound 3; then compound 2.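

In this assay, putting 3,4-dimethoxyphenyl in place of 4-fluorophenyl gives a 3.8-fold lower number from compound 3 to compound 4 (0.58 log units; beyond the scatter) on an otherwise unchanged compound. Going by these compounds alone, this is the first direct sign that the group at this aromatic carbon affects the read-out, and the larger group with two hydrogen-bond acceptors is the better of the two tested here. Nothing available explains this modest gain.

As far as these compounds go, it remains open whether both methoxy groups are needed. How an amine or a carboxylic acid would read at this same place is also unsettled.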